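The source may hold more compounds than are shown below. What is called first, only, known or untested is meant among the compounds shown, and "the series" means these compounds.

Measured so far: compound 1 `CC(C)n1nc(-c2cc(C3CCCCC3)on2)c2c(N)ncnc21` gives 9500 nM in an assay on BaF3 cells for inhibition of proto-oncogene tyrosine-protein kinase receptor Ret (Homo sapiens), read by MTT assay, with a stated time of 48 h; on this read-out lower numbers stand for stronger inhibition of growth and higher numbers for weaker inhibition of growth; compound 2 `CC(C)n1nc(-c2cc(-c3ccccc3)on2)c2c(N)ncnc21` gives 3460 nM. Compound 3 `CC(C)n1nc(-c2cc(-c3ccc(F)cc3)on2)c2c(N)ncnc21` reaches only a limit of this assay, > 10000 nM, so for compound 3 there is no number, only a limit (the limit of > 10000 nM in this assay, at which 1 of the 3 values shown sits).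

Compound 4 `CCc1cc(-c2nn(C(C)C)c3ncnc(N)c23)no1` differs from compound 3 by ethyl in place of 4-fluorophenyl on an aromatic carbon. Within the data shown here, no measured step swaps an aromatic for a small aliphatic group; the nearest is the opposite direction, a 2.7-fold lower number from compound 1 to compound 2 (0.44 log units; beyond the scatter), and an at least 2.8-fold higher number from compound 2 to compound 3 (0.46 log units; beyond the scatter) shows that the fluoro already pushed compound 3 to the limit. Compound 4 is therefore expected to remain weak, with a step that the limit leaves unreadable from compound 3 to compound 4 expected to be no step beyond the scatter. Compound 4 is estimated at 12000 nM, between 4000 nM and 35000 nM.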

Compound 4, concentration for 50% growth inhibition: 1560 nM
For compound 4 the middle estimate is 7.7-fold (0.89 log units) above the measured one; measured number below the stated range.
By their numbers in this assay, from the lowest: compound 4; then compound 2; then compound 1. At a limit, above all of these: compound 3.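

In this assay, ethyl, which carries no ring, gives the lowest number yet on this aromatic carbon next to the ring oxygen, below phenyl (a 2.2-fold lower number from compound 2 to compound 4 (0.35 log units; beyond the scatter)) and cyclohexyl (a 6.1-fold lower number from compound 1 to compound 4 (0.78 log units; beyond the scatter)). Compound 1, compound 2 and compound 3 all carry a ring here, so only compound 4 shows that a ring on this carbon is not required for this level of growth inhibition. Against 4-fluorophenyl the change reads only as a floor (an at least 6.4-fold lower number from compound 3 to compound 4 (0.80 log units; beyond the scatter)), since compound 3 stands at a limit: the limit of > 10000 nM in this assay, at which 1 of the 4 values shown sits.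

On these data alone, whether a methyl, a longer chain or an amine on this carbon would lower the number further remains open.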